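Three Limits and a Trifluorophenyl Newcomer

The compounds below may be only part of what the source reports. "The series", "measured", "known", "first", "only" and "open" are said of these compounds alone.

Compound 2 `COc1cccc(/C=C2\SC(=S)N(NS(=O)(=O)c3ccccc3)C2=O)c1` was tested in a functional assay on ECV-304 cells (Homo sapiens) for cytotoxicity; a higher number here means a weaker inhibitor, a lower number a stronger inhibitor. In this assay compound 2 gives > 50000 nM, which is a limit of the assay and not a number. Compound 1 `Cc1ccc(S(=O)(=O)NN2C(=S)S/C(=C\c3ccc(Cl)c(Cl)c3)C2O)cc1` is a close relative of the same core. Compound 1 gives > 50000 nM, likewise only a limit. Compound 3 `O=C1/C(=C/c2ccc(Br)c(Br)c2)SC(=S)N1NS(=O)(=O)c1ccccc1` carries a 3,4-dibromophenyl on the same carbon. Compound 3 gives > 50000 nM, once more a limit. Among the compounds with values here, the single change that can be followed between measured compounds is a step that the two limits leave unreadable from compound 2 to compound 3. Because (the limit of > 50000 nM in this assay, at which 3 of the 3 values shown sit), no size can be read for that step, and compound 2 stands exactly where the other two measured compounds stand, at the edge of what the assay reports.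

Compound 4 `O=C1/C(=C/c2ccc(F)c(F)c2F)SC(=S)N1NS(=O)(=O)c1ccccc1` differs from compound 2 in one place: 2,3,4-trifluorophenyl in place of 3-methoxyphenyl on a double-bonded chain carbon bound to a double-bonded ring carbon

Within the data shown here, the only measured step that bears on this change, the one from compound 2 to compound 3, exchanged one aryl group for another on that same carbon and produced nothing readable. Any expectation for compound 4 therefore rests on three limits and no readable step, so no shift beyond the scatter is expected in this assay.

Compound 4 is expected to give about 80000 nM, within a range from 30000 nM to 300000 nM. That amounts to an expected step that the limit leaves unreadable from compound 2 to compound 4, most probably reported as yet another limit.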

Compound 4, half-maximal inhibitory concentration: > 50000 nM
Compound 4: no number, only a limit; the forecaster's own chance of this, stated with the estimate: 85%; the middle value is on the limit's open side.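

No size can be read for the steps joining compound 4 to compound 2 and compound 3, because all these results stop at the same edge: the limit of > 50000 nM in this assay, at which 4 of the 4 values shown sit.

The compounds shown leave open whether any aryl group on this carbon, or any change elsewhere on the shared core, would bring a result in this assay within the range that can be reported as a number.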